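Ethoxy to hexylsulfanyl: expected cytotoxicity of compound 4

A few compounds are considered here, and "the series" means these few. Any claim that something is new, unique, unknown or untested is made for them only; others in the source may bear on it.

Compound 1, `Nc1nc(OCC(F)(F)F)c2ncn(/C=C3/CC3(CO)CO)c2n1`: > 20000 nM
Compound 2, `CCOc1nc(N)nc2c1ncn2/C=C1/CC1(CO)CO`: > 20000 nM
Compound 3, `CN(C)c1nc(N)nc2c1ncn2/C=C1/CC1(CO)CO`: "not determined" (no result reported)

In an ADME assay on MOLT-3 cells (Homo sapiens) for cytotoxicity, with a stated time of 7 days (on this read-out lower numbers stand for higher toxicity in this test and higher numbers for lower toxicity in this test), compound 1 shows > 20000 nM, which is a limit of the test rather than a number. Compound 2 likewise shows only the limit > 20000 nM in this assay. Compound 3 shows "not determined" (no result reported) in this assay. The step that the two limits leave unreadable from compound 1 to compound 2 is therefore unreadable. Compound 2 thus stands at the limit of > 20000 nM in this assay, at which 2 of the 3 values shown sit, with no numbered value beside it. Compound 4, `CCCCCCSc1nc(N)nc2c1ncn2/C=C1/CC1(CO)CO`, differs from compound 2 by hexylsulfanyl in place of ethoxy on an aromatic carbon. Among the measured compounds shown here, no measured step involves a hexylsulfanyl group, so no size can be taken from the data. Compound 4 is expected to give 20000 nM, between 5000 nM and 60000 nM. The expected step of a number no higher from compound 2 to compound 4 (the limit leaves the size open) is accordingly close to no change.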

Compound 4, half-maximal cytotoxic concentration: > 20000 nM
Compound 4 was reported as a limit (the forecaster's own chance of this, stated with the estimate: 60%); the middle value lies on the limit itself.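

No step can be read between compound 1, compound 2 and compound 4 in this assay: each gives only a limit of the test, not a number. The compounds shown leave open whether hexylsulfanyl in place of ethoxy changes cytotoxicity at all.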